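From 2,3-dichlorophenyl to 1H-pyrrol-2-yl on compound 3

The source may report more compounds than this note shows. Statements on the series, on what has been measured and on what is new or still open speak of the compounds shown alone.

In a functional assay on DU-145 cells (Homo sapiens) for inhibition, read by trypan blue exclusion, with a stated time of 96 h (on this read-out higher numbers stand for weaker inhibition of growth and lower numbers for stronger inhibition of growth), compound 3 (`O=C(/C(=C\c1cccc(Cl)c1Cl)SCc1ccc(Cl)cc1)c1ccc(Cl)cc1`) gives 10000 nM and sits level with compound 2 (`Cc1ccc(S/C(=C/c2ccc[nH]2)C(=O)c2ccc(Cl)cc2)cc1`) at 10000 nM as the highest of the three numbers, whereas compound 1 (`COc1ccccc1/C=C(/SCc1ccc(Cl)cc1)C(=O)c1ccc(Cl)cc1`) gives 1000 nM as the lowest. Compound 4 (`O=C(/C(=C\c1ccc[nH]1)SCc1ccc(Cl)cc1)c1ccc(Cl)cc1`) has 1H-pyrrol-2-yl in place of 2,3-dichlorophenyl on a double-bonded chain carbon bound to a double-bonded chain carbon. Among the compounds with values here, the one measured step at this place (a 10-fold higher number from compound 1 to compound 3 (1.00 log units; beyond the scatter)) was modest but beyond the scatter. Compound 2 carries the same 1H-pyrrol-2-yl and gives 10000 nM though the rest of it differs. Only a slightly lower number in this assay is therefore expected, within the scatter (a 2.0-fold lower number from compound 3 to compound 4 (0.30 log units; within the scatter)). Compound 4 is estimated at 5000 nM with an expected range from 1000 nM to 20000 nM overall.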

Compound 4, concentration for 50% growth inhibition: 10000 nM
Compound 4: the middle estimate sits 2.0-fold (0.30 log units) below what was measured, and the stated range covers the measured number.
By their numbers in this assay, from the lowest: compound 1; then compounds 2, 3 and 4 (each within the scatter of the next).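

At the double-bonded chain carbon, 1H-pyrrol-2-yl and 2,3-dichlorophenyl are not told apart in this assay, which shows no change at the digits printed from compound 3 to compound 4 (within the scatter), and on the sulfur, 4-chlorobenzyl in place of 4-methylphenyl gives no change at the digits printed from compound 2 to compound 4 (within the scatter). Only 2-methoxyphenyl stands apart at the chain carbon, with a 10-fold higher number from compound 1 to compound 4 (1.00 log units; beyond the scatter). No measurement at hand accounts for this difference. The compounds shown leave open whether a phenyl carrying an amine or a carboxylic acid at this place would read like compound 1 or like compound 4.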